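The source may hold more compounds than are shown below. What is called first, only, known or untested is meant among the compounds shown, and "the series" means these compounds.

Measured compounds:

Compound 1 `O=C(CSc1nnc(-c2ccncc2)o1)N/N=C/c1ccc([N+](=O)[O-])cc1`, with 17900 nM in a functional assay on HepG2 cells (Homo sapiens) for cytotoxicity, read by MTT assay, with a stated time of 48 h; on this read-out lower numbers stand for stronger inhibition and higher numbers for weaker inhibition.
Compound 2 `O=C(CSc1nnc(-c2ccncc2)o1)N/N=C/c1ccc(O)cc1`, with 5510 nM in this assay.
Compound 3 `O=C(CSc1nnc(-c2ccncc2)o1)N/N=C/c1ccccc1[N+](=O)[O-]`, with 24700 nM in this assay.

Compound 3 gives the highest number of the three. Its nearest neighbour is compound 1, separated by a 1.4-fold higher number from compound 1 to compound 3 (0.14 log units; within the scatter), a gap that does not count as a real difference. Its furthest is compound 2, separated by a 4.5-fold higher number from compound 2 to compound 3 (0.65 log units; beyond the scatter), which does.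

Compound 4 `O=C(CSc1nnc(-c2ccncc2)o1)N/N=C/c1cc(Cl)cc(Cl)c1O` has not been measured. It differs from compound 3 in one place: 3,5-dichloro-2-hydroxyphenyl in place of 2-nitrophenyl on a carbon with a double bond to nitrogen.

Among the compounds with values here, two measured steps bear on this change, and both turn on a hydroxy group replacing a nitro group on the aromatic ring attached to the carbon with a double bond to nitrogen. One is a 3.2-fold lower number from compound 1 to compound 2 (0.51 log units; beyond the scatter). The other, read in reverse, is a 4.5-fold higher number from compound 2 to compound 3 (0.65 log units; beyond the scatter). Both point the same way: the hydroxy compound gives the lower number. Within the data shown here, the two chlorine atoms that also enter have no counterpart among the measured compounds, so their effect is unknown.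

Compound 4 is therefore expected to give a lower number than compound 3 in this assay, a step of about a 3.1-fold lower number from compound 3 to compound 4 (0.49 log units; beyond the scatter). The estimate for compound 4 is 8000 nM, within a range from 2500 nM to 25000 nM.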

Compound 4, half-maximal inhibitory concentration: 3260 nM
Estimate against measurement, compound 4: 2.5-fold (0.39 log units) above; the measured number falls inside the stated range.
By their numbers in this assay, from the lowest: compounds 4 and 2 (each within the scatter of the next); then compounds 1 and 3 (each within the scatter of the next).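

In this assay, putting 3,5-dichloro-2-hydroxyphenyl in place of 2-nitrophenyl on the carbon with a double bond to nitrogen gives a 7.6-fold lower number from compound 3 to compound 4 (0.88 log units; beyond the scatter) in this series, and the same ring in place of 4-nitrophenyl gives a 5.5-fold lower number from compound 1 to compound 4 (0.74 log units; beyond the scatter), so among these four compounds every step from a nitrophenyl ring to a hydroxy-bearing ring now lowers the number. Set against 4-hydroxyphenyl, however, the new ring shows no real difference, with a 1.7-fold lower number from compound 2 to compound 4 (0.23 log units; within the scatter) lying within the scatter, so at this position the two chlorine atoms and the different hydroxyphenyl pattern together add nothing that can be told apart from compound 2 in this assay. Nothing on hand says what lies behind these numbers.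

From the compounds shown here alone, whether the chlorine atoms count on their own stays open, and a plain 2-hydroxyphenyl ring, compared with compound 4, would separate their contribution from that of the hydroxy group. Going by these compounds, how a ring carrying an amine or a carboxylic acid would read at this position also remains unknown, as does whether the trend holds on a changed core.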